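Clearance at the acyl group: from compound 3 to compound 4

A few compounds are considered here, and "the series" means these few. Any claim that something is new, unique, unknown or untested is made for them only; others in the source may bear on it.

In an ADME assay on the whole organism (strain Sprague-Dawley) for pharmacokinetics, with Rattus norvegicus as the target, read by LC-MS, using cassette dosing, at a dose of 0.5 mg/kg by the intravenous route (on this read-out higher numbers stand for fast clearance and lower numbers for slow clearance), compound 3 (`C[C@@]1(c2cc(NC(=O)c3ncc(OCF)nc3N)ccc2F)C=C(CF)OC(N)=N1`) gives 45.3 mL/min/kg and sits among the three numbers at the level of compound 2. Compound 2 (`C[C@@]1(c2cc(NC(=O)c3cnc(C(F)F)cn3)ccc2F)C=C(CF)OC(N)=N1`) gives 48.1 mL/min/kg and lies within the scatter of compound 3, while compound 1 (`COCC1=C[C@@](C)(c2cc(NC(=O)c3ccc(C#N)cn3)ccc2F)N=C(N)O1`) gives 12.9 mL/min/kg and stands clearly lower than compound 3.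

Compound 4 (`COc1cc(C#N)cnc1C(=O)Nc1ccc(F)c([C@]2(C)C=C(CF)OC(N)=N2)c1`) carries 5-cyano-3-methoxypyridin-2-yl in place of 3-amino-5-(fluoromethoxy)pyrazin-2-yl on a carbonyl carbon. Going by the values given here, the only measured step at this place is a 1.1-fold lower number from compound 2 to compound 3 (0.03 log units; within the scatter) and it gives no sign of a large move on exchanging this group. Compound 1 also holds a nitrile in its group at this place, yet it differs from compound 4 at a second place as well, so it pulls the expectation down only slightly. The expected change is a 1.3-fold lower number from compound 3 to compound 4 (0.10 log units; within the scatter) and no step beyond the scatter is expected. For compound 4 the estimate is 36 mL/min/kg with an expected range from 17 mL/min/kg to 68 mL/min/kg in this assay for now.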

Compound 4, clearance: 36.6 mL/min/kg
The estimate for compound 4 lay 1.0-fold (0.01 log units) below the measured number, within the range that was stated.
By their numbers in this assay, from the lowest: compound 1; then compounds 4, 3 and 2 (each within the scatter of the next).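

In this assay, the acyl group tolerates a change of ring as well as of substituent: a 1.2-fold lower number from compound 3 to compound 4 (0.09 log units; within the scatter), and a 1.3-fold lower number from compound 2 to compound 4 (0.12 log units; within the scatter). The earlier step covered two pyrazines only, whereas compounds 2, 3 and 4 now show that a pyridine carrying a nitrile and a methoxy group, with 0 hydrogen-bond donors, also stays within the scatter at this place on the carbonyl carbon. No supporting data are available to explain this flat read-out.

Compound 1 differs from compound 4 in two places, so the value of compound 1, 12.9 mL/min/kg, cannot be assigned to either place. Also open, on these data alone, is whether a carboxylic acid or a primary amine on the acyl ring would move clearance beyond the scatter on this core.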